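The compounds below may be only part of what the source reports. "The series", "measured", "known", "first", "only" and "open" are said of these compounds alone.

Compound 1 (`c1cc([C@H]2CC[C@]3(CC2)OOC2(O3)C3CC4CC(C3)CC2C4)ccc1OCCC1CCNCC1`) gives > 100 ug/mL in a physicochemical assay for solubility, read by nephelometry, measured as kinetic solubility, with a stated time of 30 min (a lower number here means a less soluble compound, a higher number a more soluble compound), which is a limit of the assay and not a number. It stands highest of the measured compounds, with no exact value to start from. Compound 2 (`NC1CCN(S(=O)(=O)c2ccc([C@H]3CC[C@]4(CC3)OOC3(O4)C4CC5CC(C4)CC3C5)cc2)CC1`) gives 12.5 ug/mL, and compound 3 (`N[C@H]1CC[C@@H](Oc2ccc([C@H]3CC[C@]4(CC3)OOC3(O4)C4CC5CC(C4)CC3C5)cc2)CC1`) gives 25 ug/mL. These two differ by a 2.0-fold higher number from compound 2 to compound 3 (0.30 log units; within the scatter), so they sit at one level.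

Compound 4 (`CC1(C)CC(O)(COc2ccc([C@H]3CC[C@]4(CC3)OOC3(O4)C4CC5CC(C4)CC3C5)cc2)CC(C)(C)N1`) keeps the core of compound 1 and alters only the side chain: 4-hydroxy-2,2,6,6-tetramethylpiperidin-4-yl in place of (piperidin-4-yl)methyl on a saturated chain carbon bound to an oxygen on an aromatic ring. The new group sits on a saturated chain carbon bound to an oxygen on an aromatic ring.

Going by the values given here, two measured steps bear on this change, since both replace the side chain of compound 1. One is an at least 8.0-fold lower number from compound 1 to compound 2 (0.90 log units; beyond the scatter). The closer one keeps the oxygen on the aromatic ring and is an at least 4.0-fold lower number from compound 1 to compound 3 (0.60 log units; beyond the scatter). Both went down, and both sizes are only minimums. Compound 4 differs from compound 3 in its side chain, and only these two replacements are available as a guide. A fall in this assay beyond the scatter is therefore expected, probably smaller than those steps or similar to them, though a result at the limit remains possible. The estimated change is an at least 2.5-fold lower number from compound 1 to compound 4 (0.39 log units; beyond the scatter). For compound 4 the expected value is 40 ug/mL, with an estimated range of 12 ug/mL to 100 ug/mL.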

Compound 4, solubility: > 100 ug/mL
Compound 4: a limit, no number; the forecaster's own chance of this, stated with the estimate: 25%; middle value at least 2.5-fold (0.39 log units) away from the limit.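

In this assay compound 4 gives > 100 ug/mL, which is a limit of the assay and not a number. The size of any change from compound 1 to compound 4 cannot be read, because both compounds rest on the same limit: the limit of > 100 ug/mL in this assay, at which 2 of the 4 values shown sit.

Going by these compounds alone, replacing 4-aminocyclohexyl with (4-hydroxy-2,2,6,6-tetramethylpiperidin-4-yl)methyl on the oxygen on the aromatic ring gives an at least 4.0-fold higher number from compound 3 to compound 4 (0.60 log units; beyond the scatter), so compound 4 is the first replacement for the side chain of compound 1 that shows no readable fall, unlike compound 2 and compound 3, even though the entering group has 11 heavy atoms where the group it replaces has 7.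

The compounds shown do not separate the part played by the hydroxyl from that of the four methyl groups, a question that 4-hydroxypiperidin-4-yl and 2,2,6,6-tetramethylpiperidin-4-yl on the same saturated chain carbon would address. Going by these compounds, how far compound 1 and compound 4 lie past the limit also stays open, as does the reading for a side chain ending in a carboxylic acid rather than an amine.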